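This account rests on a few compounds, and the source may have more. Where it says the series, first, only, none or still open, it means among the compounds named here.

Values in an ADME assay on Raji cells (Homo sapiens) for cytotoxicity, with a stated time of 72 h; on this read-out higher numbers stand for an effect only at larger amounts of compound and lower numbers for an effect already at smaller amounts:
- Compound 1 `Cc1cc(NC(=O)Nc2ccc(C)c(Cl)c2)c2ccccc2n1`: > 25000 nM (a limit)
- Compound 2 `Cc1cc(NC(=O)Nc2ccc(Cl)c(Cl)c2)c2ccccc2n1`: 10000 nM
- Compound 3 `CSc1ccc(NC(=O)Nc2cc(C)nc3ccccc23)cc1`: > 25000 nM (a limit)

Compound 3 stands at > 25000 nM in this assay. That value is a limit and not a number, and one other compound in the set also reads as a limit.

Compound 4 `Cc1ccc(NC(=O)Nc2cc(C)nc3ccccc23)cc1` differs from compound 3 in one place: methyl in place of methylsulfanyl on an aromatic carbon, para to a large group (methyl in place of methylsulfanyl on an aromatic carbon).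

Among the compounds with values here, only one measured step is available, and it bears on this change loosely. It is an at least 2.5-fold lower number from compound 1 to compound 2 (0.39 log units; beyond the scatter), with chloro in place of methyl on an aromatic carbon. There methyl leaves and the number falls, whereas here methyl enters and chloro plays no part. That step therefore gives no reason to expect a fall for compound 4, and no measured step involves methylsulfanyl. More weight falls on (the limit of > 25000 nM in this assay, at which 2 of the 3 values shown sit).

No step beyond the scatter is expected, and the estimated change is a number no higher from compound 3 to compound 4 (the limit leaves the size open). A further limit is the most likely report. For compound 4 the estimated value is 25000 nM, with an expected range from 12000 nM to 50000 nM.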

Compound 4, half-maximal effective concentration: > 25000 nM
Compound 4 gave a limit, no number; the forecaster's own chance of this, stated with the estimate: 70%; the middle value lies on the limit itself.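

In this assay compound 4 gives > 25000 nM, a limit and not a number. Compound 1 and compound 3 also stand at limits, so the steps to compound 4 from each of them cannot be read. The compounds shown leave open whether methyl in place of methylsulfanyl changes the read-out at all, and the values offer only this: the limit of > 25000 nM in this assay, at which 3 of the 4 values shown sit.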